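The source may hold more compounds than are shown below. What is called first, only, known or untested is meant among the compounds shown, and "the series" means these compounds.

Measured so far:
compound 1, `CC(Br)C(=O)Nc1ccc(C(=O)/C=C/c2ccc(Cl)cc2)cc1`, 39%
compound 2, `COc1ccc(/C=C/C(=O)c2ccc(NC(=O)C(C)Br)cc2)cc1`, 39%
compound 3, `CC(O[N+](=O)[O-])C(=O)Nc1ccc(C(=O)/C=C/c2ccc(Cl)cc2)cc1`, 45%

All three were tested in a functional assay on the whole organism (strain albino) for inhibition, with Rattus norvegicus as the target, read by paw edema, with stated times of 30 min and 1 h, at a dose of 100 mg/kg by the oral route; on this read-out higher numbers stand for more inhibition at the one dose given (going by the name of the read-out) and lower numbers for less inhibition. Compound 4, `COc1ccc(/C=C/C(=O)c2ccc(NC(=O)C(C)O[N+](=O)[O-])cc2)cc1`, has not yet been measured there.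

Two changes run through the set. The first leads from compound 1 to compound 2: methoxy in place of chloro on an aromatic carbon. Its effect was no change at the digits printed from compound 1 to compound 2 (within the scatter). The second leads from compound 1 to compound 3: nitrooxy in place of bromo on a saturated chain carbon bound to a carbonyl carbon and a saturated chain carbon. Here the result was a number 6 percentage points higher from compound 1 to compound 3 (within the scatter). Compound 3 carries the highest number of the three, but its gaps to compound 1 and to compound 2 both lie within the scatter, so no ranking follows from them.

Compound 4 arises from compound 3 by the same change that leads from compound 1 to compound 2: methoxy in place of chloro on an aromatic carbon. The place is worded identically in both cases, so this is the same change, now made on the core of compound 3, which differs from the core of compound 1 only by the exchange described for compound 3. Going by the values given here, the one measured instance of this change moved the read-out by nothing beyond the scatter, and nothing in the data suggests that the core of compound 3 should respond differently. Among the compounds with values here, the expected step is a number 1 percentage points lower from compound 3 to compound 4 (within the scatter), since the only measured instance of this change gave no change at the digits printed from compound 1 to compound 2 (within the scatter). For compound 4 the estimate in this assay is 44%, with most repeats expected between 34% and 54%.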

Compound 4, a percentage reported as inhibition, in the whole organism at one dose (the size of the read-out at that dose, not a potency): 43%
Estimate against measurement, compound 4: 1 percentage points above, within the range that was stated.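

In this assay, methoxy in place of chloro on the core of compound 3 gave a number 2 percentage points lower from compound 3 to compound 4 (within the scatter), and this step reads the same as the earlier one on the core of compound 1: the same change on two cores in this assay, no change at the digits printed (within the scatter) from compound 1 to compound 2 and a number 2 percentage points lower (within the scatter) from compound 3 to compound 4, 2 percentage points apart, within the scatter of two such steps

Nitrooxy in place of bromo, now on the core of compound 2, gave a number 4 percentage points higher from compound 2 to compound 4 (within the scatter), and this change also reads the same on both cores: the same change on two cores in this assay, a number 6 percentage points higher (within the scatter) from compound 1 to compound 3 and a number 4 percentage points higher (within the scatter) from compound 2 to compound 4, 2 percentage points apart, within the scatter of two such steps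

So on these two pairs of cores, neither change takes the read-out beyond the scatter on either core, and the four compounds give no sign that one change alters the outcome of the other, but this does not show that either change has a real effect of a fixed size that would carry to further cores, as steps inside the scatter offer no clear effect to carry.

The compounds shown leave open whether another group on the aromatic carbon, such as an amine or a carboxylic acid, or a longer chain on the saturated chain carbon that carries bromo or nitrooxy, would move the read-out beyond the scatter. From the compounds shown here alone, every number here is also a read-out at a single dose, so potency remains open for all four compounds.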